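The compounds below may be only part of what the source reports. "The series", "measured", "known", "first", "only" and "open" are said of these compounds alone.

In a functional assay on HUVEC cells (Homo sapiens) for cytotoxicity (a higher number here means that more compound is needed for the effect, a lower number that less compound is needed), compound 2 `COC1=C(C)C(=O)/C(=C(O)/C=C/c2c(C)cccc2C)C(=O)C1(C)C` gives 3 ug/mL and compound 1 `COC1=C(C)C(=O)/C(=C(O)/C=C/c2cccc(OC)c2)C(=O)C1(C)C` gives 1.6 ug/mL, two values within the usual scatter of each other. Compound 3 `C=Cc1ccccc1/C=C/C(O)=C1/C(=O)C(C)=C(OC)C(C)(C)C1=O` carries a new group at the same place: 2-vinylphenyl in place of 2,6-dimethylphenyl on a double-bonded chain carbon bound to a double-bonded chain carbon. Among the measured compounds shown here, the only measured step at this place is a 1.9-fold higher number from compound 1 to compound 2 (0.27 log units; within the scatter), and it stays within the scatter. With just this one step as a guide, no change beyond the scatter is expected in this assay. The expected step is a 1.3-fold lower number from compound 2 to compound 3 (0.12 log units; within the scatter). Compound 3 is estimated at 2.3 ug/mL, with an expected range from 0.9 ug/mL to 6 ug/mL.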

Compound 3, concentration for half-maximal effect: 1.1 ug/mL
Compound 3: middle estimate off by 2.1-fold (0.32 log units), on the high side, within the range that was stated.
By their numbers in this assay, from the lowest: compounds 3, 1 and 2 (each within the scatter of the next, the first and the last beyond it).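

In this assay this position now shows a step beyond the scatter: 2-vinylphenyl in place of 2,6-dimethylphenyl gives a 2.7-fold lower number from compound 2 to compound 3 (0.44 log units; beyond the scatter), a modest change. The same group in place of 3-methoxyphenyl gives a 1.5-fold lower number from compound 1 to compound 3 (0.16 log units; within the scatter), which stays within the scatter, so only compound 2 and compound 3 are clearly separated. Nothing available explains this difference. Still open, going by these compounds, is how a phenyl carrying an amine or a carboxylic acid would behave at this place, and whether the number could move further in either direction.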